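Piperidine for ethylpiperazine on the anilino ring: expected step

A few compounds are considered here, and "the series" means these few. Any claim that something is new, unique, unknown or untested is made for them only; others in the source may bear on it.

Compound 1 `CCN1CCN(c2ccc(Nc3ncc(Cl)c(Nc4ccccc4C)n3)nc2)CC1` carries a 4-ethylpiperazin-1-yl group on a six-membered aromatic ring with one nitrogen. In a functional assay on MCF7 cells (Homo sapiens) for inhibition, read by CCK-8 assay, with a stated time of 48 h (on this read-out higher numbers stand for weaker inhibition of growth and lower numbers for stronger inhibition of growth), compound 1 gives only a limit, > 100000 nM, not a number. Compound 2 `Cc1ccccc1Nc1nc(Nc2ccc(N3CCCCC3)cn2)ncc1Cl` differs by piperidin-1-yl in place of 4-ethylpiperazin-1-yl on an aromatic carbon, and in this assay compound 2 gives 21400 nM. The step is an at least 4.6-fold lower number from compound 1 to compound 2 (0.66 log units; beyond the scatter); its size rests on the compound 1 side being the limit (the limit of > 100000 nM in this assay, at which 1 of the 3 values shown sits).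

Compound 3 `CCN1CCN(c2ccc(Nc3ncc(Cl)c(Nc4ccccc4C)n3)cc2)CC1` keeps the 4-ethylpiperazin-1-yl group but on a six-membered aromatic ring of carbon only; in this assay compound 3 gives 3160 nM, the lowest of the two measured numbers, with compound 2 higher by a gap beyond the scatter. How the core of compound 3 differs from the core of compound 1 is not broken down here.

Compound 4 `Cc1ccccc1Nc1nc(Nc2ccc(N3CCCCC3)cc2)ncc1Cl` is not yet measured. It differs from compound 3 by piperidin-1-yl in place of 4-ethylpiperazin-1-yl on an aromatic carbon. This is the same kind of change as that from compound 1 to compound 2, not the same: there the place was on a six-membered aromatic ring with 1 nitrogen, two atoms from the ring nitrogen, para to a large group; here it is on a six-membered aromatic ring of carbon only, para to a large group.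

The expected step is a 3.2-fold lower number from compound 3 to compound 4 (0.50 log units; beyond the scatter), somewhat smaller than an at least 4.6-fold lower number from compound 1 to compound 2 (0.66 log units; beyond the scatter) because that earlier step rests on a limit, (the limit of > 100000 nM in this assay, at which 1 of the 3 values shown sits), and its true size is not known. Compound 4 is estimated at 1000 nM in this assay, expected between 300 nM and 3500 nM.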

Compound 4, concentration for 50% growth inhibition: > 100000 nM
Compound 4 gave a limit, no number; the forecaster's own chance of this, stated with the estimate: 3%; middle value at least 100-fold (2.00 log units) away from the limit.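

Piperidin-1-yl in place of 4-ethylpiperazin-1-yl does not carry over from one core to the other in this assay, since the step on the two cores points in opposite directions: the same change on two cores in this assay, an at least 4.6-fold lower number (0.66 log units; beyond the scatter) from compound 1 to compound 2 and an at least 31-fold higher number (1.50 log units; beyond the scatter) from compound 3 to compound 4, at least 140-fold (2.16 log units) apart, beyond the scatter of two such steps

On the six-membered aromatic ring of carbon only, the change gives an at least 31-fold higher number from compound 3 to compound 4 (1.50 log units; beyond the scatter), which shows that the outcome of this exchange depends on the core in this small set, but not which feature of the core sets it.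

Compound 4 gives only a limit, > 100000 nM, not a number, so the new step has no upper end and the true sizes of both steps remain unknown: the limit of > 100000 nM in this assay, at which 2 of the 4 values shown sit.

Only 4-ethylpiperazin-1-yl and piperidin-1-yl appear at this place in the compounds shown, so it remains open whether morpholine or unsubstituted piperazine would follow either of them on each of the two cores. Also open, from the compounds shown here alone, is whether a longer chain or a hydroxyethyl group in place of the ethyl group would keep the growth inhibition seen on the carbon-only ring, and whether any such group would give a measurable number on the core of compound 1.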